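Amide chain extension in the shared-core series

A few compounds are considered here, and "the series" means these few. Any claim that something is new, unique, unknown or untested is made for them only; others in the source may bear on it.

Measured compounds:
compound 1, `COc1cc2c(cc1OC)C(CC(=O)O)CC2`, gives 26.7% in a functional assay on the whole organism (strain Wistar) for inhibition, with Rattus norvegicus as the target, read by paw edema, with stated times of 60 min and 24 h, at a dose of 100 mg/kg by the oral route; on this read-out lower numbers stand for less inhibition and higher numbers for more inhibition at the one dose given (going by the name of the read-out).
compound 2, `CCCCNC(=O)CC1CCc2cc(OC)c(OC)cc21`, gives 36.7% in this assay.

For the measured compounds named here, compound 2 stands at the higher of the two numbers, with compound 1 as its only neighbour; the single step between them, a number 10 percentage points higher from compound 1 to compound 2 (within the scatter), is within the scatter, so the two compounds cannot be told apart on this read-out.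

Compound 3, `CCCCCNC(=O)CC1CCc2cc(OC)c(OC)cc21`, is not yet measured. It differs from compound 2 by methyl in place of hydrogen on a saturated chain carbon, four bonds along the chain from an amide-type nitrogen. Going by the values given here, no measured step touches this part of the molecule: the one step on record exchanges butylamino for hydroxy on the carbonyl carbon, not a carbon on the chain, and it was itself within the scatter. There is therefore nothing to support a move beyond the scatter in either direction, and the working expectation for compound 3 is a number close to that of compound 2, an estimated step of a number 0.3 percentage points higher from compound 2 to compound 3 (within the scatter). On that basis compound 3 is estimated at 37%, with a range from 22% to 52%.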

Compound 3, a percentage reported as inhibition, in the whole organism at one dose (the size of the read-out at that dose, not a potency): 46.7%
For compound 3 the middle estimate is 9.7 percentage points below the measured one; measured number inside the range.
By their numbers in this assay, from the lowest: compounds 1, 2 and 3 (each within the scatter of the next, the first and the last beyond it).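

For the compounds shown here, the methyl on the saturated chain carbon, four bonds along the chain from an amide-type nitrogen, is the first change at the far end of the amide chain, and in this assay it gives a number 10 percentage points higher from compound 2 to compound 3 (within the scatter) and so leaves butylamino and pentylamino on the carbonyl carbon indistinguishable on this read-out. Set against the acid, however, pentylamino in place of hydroxy on the carbonyl carbon gives a number 20 percentage points higher from compound 1 to compound 3 (beyond the scatter) and is the first step in the series to pass beyond the scatter, whereas butylamino in that same place stayed within it. Nothing available speaks to what lies behind either step.

The compounds shown leave open whether hexylamino or a still longer chain on the same carbonyl carbon would stand apart from pentylamino on this read-out, or whether the numbers level off at this length. Also open, from the compounds shown here alone, is how a branched chain such as isopentylamino, or a ring amine such as piperidine, would compare in that place on the shared core.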